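Ring Stereocentre Inversion and Permeability in a Sulfonamide Series

The source may report more compounds than this note shows. Statements on the series, on what has been measured and on what is new or still open speak of the compounds shown alone.

Measured compounds:
compound 1 `CC1(C)C[C@@H](CN([C@H](CCC(F)(F)F)C(N)=O)S(=O)(=O)c2ccc(Cl)cc2)O1` gives 14.9 10^-6 cm/s in an ADME assay on MDCKII-LE cells (Canis lupus familiaris) for permeability, read by transwell migration, in the apical to basolateral direction; on this read-out lower numbers stand for lower permeability and higher numbers for higher permeability;
compound 2 `CC1(C)C[C@H](CN([C@H](CCC(F)(F)F)C(N)=O)S(=O)(=O)c2ccc(Cl)cc2)O1` gives 18.1 10^-6 cm/s in this assay;
compound 3 `NC(=O)[C@@H](CCC(F)(F)F)N(C[C@H]1CCCCO1)S(=O)(=O)c1ccc(Cl)cc1` gives 13.4 10^-6 cm/s in this assay.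

Compound 3 sits in the same range as the other two: the gap a 1.1-fold lower number from compound 1 to compound 3 (0.05 log units; within the scatter) and the gap a 1.4-fold lower number from compound 2 to compound 3 (0.13 log units; within the scatter) both fall inside the usual scatter of this assay. Compound 4 `NC(=O)[C@@H](CCC(F)(F)F)N(C[C@@H]1CCCCO1)S(=O)(=O)c1ccc(Cl)cc1` has not yet been measured. Its relation to compound 3 is the two compounds have the same atoms and bonds and differ only in configuration as drawn: 1 of 2 stereo elements differ; a stereocentre at a saturated ring carbon is drawn R in compound 3 and S in compound 4.

One measured step speaks directly to this change, because the fact that compounds 1 and 2 differ only in the configuration as drawn describes the same kind of inversion at a saturated ring carbon. That step, a 1.2-fold higher number from compound 1 to compound 2 (0.08 log units; within the scatter), did not leave the scatter. The replacement of the ring itself, seen in the steps from compound 1 and compound 2 to compound 3, also stayed within scatter. No step beyond the scatter is therefore expected from compound 3 to compound 4 in this assay, and the expected step is a 1.0-fold higher number from compound 3 to compound 4 (0.02 log units; within the scatter). Compound 4 is estimated at 14 10^-6 cm/s, within a range of 8 10^-6 cm/s to 24 10^-6 cm/s.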

Compound 4, apparent permeability: 15.4 10^-6 cm/s
For compound 4 the middle estimate is 1.1-fold (0.04 log units) below the measured one; low and high end bracket the measured number.
By their numbers in this assay, from the lowest: compounds 3, 1, 4 and 2 (each within the scatter of the next).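

In this assay, inverting the saturated ring carbon of the oxan-2-yl compounds gives a 1.1-fold higher number from compound 3 to compound 4 (0.06 log units; within the scatter), so this change, previously read only on the 4,4-dimethyloxetan-2-yl pair, now has a second reading on a different ring, and it again stays within the scatter: the fact that compounds 3 and 4 differ only in the configuration as drawn. With the ring carbon drawn S, oxan-2-yl in place of 4,4-dimethyloxetan-2-yl also stays within the scatter, giving a 1.2-fold lower number from compound 2 to compound 4 (0.07 log units; within the scatter) and a 1.0-fold higher number from compound 1 to compound 4 (0.01 log units; within the scatter). Across these four compounds, neither the configuration at this carbon nor the choice between these two rings separates the values.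

The compounds leave open whether the same holds when an amine or a carboxylic acid is carried on the ring. They also leave open what a longer chain would give in place of the ring on that saturated chain carbon.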